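A Five-Membered Ring Replaces a Six-Membered One

The source may hold more compounds than are shown below. What is called first, only, known or untested is meant among the compounds shown, and "the series" means these compounds.

Of the compounds shown here, three have so far been measured in a toxicity assay on cells (Cricetulus griseus) for cytotoxicity, read by MTT assay, with a stated time of 72 h (on this read-out higher numbers stand for weaker inhibition and lower numbers for stronger inhibition), and only one of them gives a number. Compound 1 (`Cc1c(C)c2c(c(C)c1OC(=O)CCC(=O)NC1CC(C)(C)N([O])C(C)(C)C1)CC[C@@](C)(CCC[C@H](C)CCC[C@H](C)CCCC(C)C)O2`) gives > 300000 nM as a limit of the assay, not a number. Compound 2 (`Cc1c(C)c2c(c(C)c1OC(=O)CCC(=O)O)CCC(C)(C(=O)O)O2`) likewise gives > 300000 nM as a limit. Compound 3 (`Cc1c(C)c2c(c(C)c1OC(=O)CCC(=O)NC1CC(C)(C)N([O])C(C)(C)C1)CCC(C)(C(=O)NC1CC(C)(C)N([O])C(C)(C)C1)O2`) gives a measured number, 54000 nM in this assay as well. Compound 1 thus stands at the limit of > 300000 nM in this assay, at which 2 of the 3 values shown sit, and not on a measured number.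

Compound 4 (`Cc1c(C)c2c(c(C)c1OC(=O)CCC(=O)NCC1CC(C)(C)N([O])C1(C)C)CC[C@@](C)(CCC[C@H](C)CCC[C@H](C)CCCC(C)C)O2`) has not yet been measured. The change from compound 1 to compound 4 is a group of 11 heavy atoms (9 carbon, 1 nitrogen, 1 oxygen; one five-membered non-aromatic ring with 1 hetero atom) in place of a group of 11 heavy atoms (9 carbon, 1 nitrogen, 1 oxygen; one six-membered non-aromatic ring with 1 hetero atom), on an amide-type nitrogen and leaves the atoms the same but joined differently. No measured pair among these compounds differs in one place, so the data do not size such a change. In this assay no step beyond the usual scatter is expected in either direction, and the expectation starts from compound 1 at > 300000 nM as its limit. The estimated step is a number no higher from compound 1 to compound 4 (the limit leaves the size open) and the reading may again be only a limit. For compound 4 the estimated value is 300000 nM with an expected range from 120000 nM to 600000 nM on this read-out.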

Compound 4, half-maximal inhibitory concentration: > 300000 nM
Compound 4: only a limit was reported; the forecaster's own chance of this, stated with the estimate: 75%; the middle value sits exactly at the limit.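

Going by these compounds alone, compound 1 and compound 4 both give only a limit of the assay, not a number, so no step between them can be read. The compounds shown leave open how the group with the five-membered non-aromatic ring and the group with the six-membered non-aromatic ring, on an amide-type nitrogen, compare in this assay.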